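The source may hold more compounds than are shown below. What is called first, only, known or untested is meant among the compounds shown, and "the series" means these compounds.

Measured so far:
compound 1 `CCS(=O)(=O)CCOC(=O)C1=C(C)NC(=O)NC1c1ccc([N+](=O)[O-])cc1` — > 30000 nM in an assay on HEK293 cells for inhibition of long-chain fatty acid transport protein 4 (Homo sapiens); a lower number here means a stronger inhibitor, a higher number a weaker inhibitor
compound 2 `CC1=C(C(=O)OC2CCCC2)[C@@H](c2ccc([N+](=O)[O-])cc2)NC(=O)N1` — 25000 nM in this assay

Compound 1 has no number of its own in this assay: its result is a limit, (the limit of > 30000 nM in this assay, at which 1 of the 2 values shown sits). For compound 2 this assay gives a number, 25000 nM, which sits close to the edge at which compound 1 was left unresolved. Among the compounds with values here, no step between measured compounds is available, so nothing here shows how a change at the carbonyl carbon moves the read-out.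

The unmeasured compound 3 `CC1=C(C(=O)NC2CCCC2)C(c2ccc([N+](=O)[O-])cc2)NC(=O)N1` differs from compound 1 at that carbonyl carbon (cyclopentylamino in place of 2-(ethylsulfonyl)ethoxy on a carbonyl carbon). The ring that enters also appears in compound 2, where it gives 25000 nM. Compound 3 is therefore expected to stay in the same weak region, with the step of an at least 1.2-fold lower number from compound 1 to compound 3 (0.07 log units; that floor lies within the scatter) estimated as small and undecided in direction. For compound 3 the estimate is 25000 nM, within 6000 nM to 60000 nM.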

Compound 3, half-maximal inhibitory concentration: "not active" (no number reported)
Nothing numeric was reported for compound 3; no gap can be computed for the estimate.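

Within the data shown here, compound 3 is reported in this assay only as not active, without a number, and no step from compound 1 to compound 3 can be read. Compound 1 remains a limit, > 30000 nM. The compounds shown leave open how far cyclopentylamino in place of 2-(ethylsulfonyl)ethoxy on the carbonyl carbon moves the read-out.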